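Pyrazole chain end: compound 2 to compound 3

This account rests on a few compounds, and the source may have more. Where it says the series, first, only, none or still open, it means among the compounds named here.

Values in a functional assay on OVCAR-4 cells (Homo sapiens) for inhibition, read by sulforhodamine B assay, with a stated time of 48 h; a higher number here means a weaker inhibitor of growth, a lower number a stronger inhibitor of growth:
- compound 1 `CCCCCCCCCCCC[C@@H](O)[C@H]1CC[C@H]([C@H](O)CCCCCCCCCCNC(=O)c2ccnn2C)O1` gives 22900 nM
- compound 2 `CCCCCCCCCCCC[C@@H](O)[C@H]1CC[C@H]([C@H](O)CCCCCCCCCCN(C)C(=O)c2ccnn2C)O1` gives 10000 nM
- compound 3 `CCCCCCCCCCCC[C@@H](O)[C@H]1CC[C@H]([C@H](O)CCCCCCCCCCNCc2ccnn2C)O1` is not yet measured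

Compound 2 (10000 nM) holds the lower of the two numbers. Compound 3 differs from it by ((1-methyl-1H-pyrazol-5-yl)methyl)amino in place of methyl((1-methyl-1H-pyrazol-5-yl)carbonyl)amino on a saturated chain carbon, ten or more bonds along the chain from an oxygen on a saturated carbon and a saturated ring carbon and loses the carbonyl. Going by the values given here, the only measured step (a 2.3-fold lower number from compound 1 to compound 2 (0.36 log units; beyond the scatter)), methyl in place of hydrogen on an amide-type nitrogen, is modest and leaves the carbonyl in place, so it is a weak guide. Among the compounds with values here, no measured step covers loss of the carbonyl, and the direction remains open. The expected step is small (a 1.3-fold lower number from compound 2 to compound 3 (0.10 log units; within the scatter)), not clearly beyond the scatter. Compound 3 is estimated at 8000 nM (range 2500 nM to 25000 nM).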

Compound 3, concentration for 50% growth inhibition: 1580 nM
For compound 3 the middle estimate is 5.1-fold (0.70 log units) above the measured one; measured number below the stated range.
By their numbers in this assay, from the lowest: compound 3; then compound 2; then compound 1.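

In this assay, (1-methyl-1H-pyrazol-5-yl)methyl in place of (1-methyl-1H-pyrazol-5-yl)carbonyl gives a 14-fold lower number from compound 1 to compound 3 (1.16 log units; beyond the scatter), and the change from the methylated amide gives a 6.3-fold lower number from compound 2 to compound 3 (0.80 log units; beyond the scatter). Growth inhibition in this short series therefore does not depend on the carbonyl that both earlier compounds keep at this chain end. Nothing available accounts for the gain.

Still open, on these data alone, is whether a methyl on the amine nitrogen of compound 3, or a sulfonamide in place of the amine, would hold this gain. Also open, as far as these compounds go, is whether the pyrazole itself contributes, which a phenyl ring at the chain end would test.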